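A few compounds are considered here, and "the series" means these few. Any claim that something is new, unique, unknown or untested is made for them only; others in the source may bear on it.

Measured compounds:
- compound 1, `O=C(CSc1nncnc1-c1cccc2ccccc12)N1CCc2ccccc2C1`: 13000 nM
- compound 2, `O=C(CSc1nncnc1-c1cccc2ccccc12)Nc1ccccc1`: 154000 nM

In an ADME assay on MT4 cells (Homo sapiens) for cytotoxicity, read by MTT assay (a higher number here means that more compound is tolerated, a lower number that less compound is tolerated), compound 2 gives 154000 nM, the highest of the two numbers, and compound 1 gives 13000 nM. Among the measured compounds shown here, the single measured step, a 12-fold higher number from compound 1 to compound 2 (1.07 log units; beyond the scatter), concerns the group on the carbonyl carbon and is large. Compound 3, `O=C(CSc1nncnc1-c1cccc2ccccc12)Nc1cccnc1Cl`, has not been measured. It differs from compound 2 by 2-chloropyridin-3-yl in place of phenyl on an amide-type nitrogen. For the measured compounds named here, no measured step changes the aryl group on the amide-type nitrogen, so the one known step bears on compound 3 only loosely, as a sign that this part of the molecule can move the number. With nothing more to go on, a step for compound 3 in this assay of a 1.3-fold lower number from compound 2 to compound 3 (0.11 log units; within the scatter) is expected, not beyond the scatter. Compound 3 is therefore estimated at 120000 nM, between 40000 nM and 300000 nM.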

Compound 3, half-maximal cytotoxic concentration: 44000 nM
Beside the measured number, compound 3's estimate is 2.7-fold (0.44 log units) above it; the range from low to high includes it.
By their numbers in this assay, from the lowest: compound 1; then compound 3; then compound 2.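

In this assay, the group on the amide-type nitrogen proves able to move the number on its own: 2-chloropyridin-3-yl in place of phenyl gives a 3.5-fold lower number from compound 2 to compound 3 (0.54 log units; beyond the scatter). Set against the other amide, (2-chloropyridin-3-yl)amino in place of 1,2,3,4-tetrahydroisoquinolin-2-yl on the carbonyl carbon still gives a 3.4-fold higher number from compound 1 to compound 3 (0.53 log units; beyond the scatter), so part of the large rise seen with anilino remains with this group. No supporting data bear on why the number moves.

The change brings in a ring nitrogen and a chlorine together, and the compounds shown do not separate the two; a pyridin-3-yl group and a 2-chlorophenyl group would each carry only one of them. From the compounds shown here alone, how a carboxylic acid or an amine on the aromatic ring would read in this assay also remains open.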